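Pyridyl Swap on a Benzylidene Oxindole Core

The compounds below may be only part of what the source reports. "The series", "measured", "known", "first", "only" and "open" are said of these compounds alone.

Measured compounds:
compound 1, `O=C1/C(=C\c2ccccn2)c2ccccc2N1Cc1ccccc1`, 3600 nM
compound 2, `CC(c1ccccc1)N1C(=O)/C(=C\c2cccnc2)c2ccccc21`, 3300 nM

Both were tested in a functional assay on HL-60 cells (Homo sapiens) for cytotoxicity, read by MTT assay, with a stated time of 72 h; on this read-out lower numbers stand for stronger inhibition and higher numbers for weaker inhibition. Compound 2 gives 3300 nM, and this number sits within the scatter of the number for compound 1, so neither compound can be placed ahead of the other. Compound 3, `CC(c1ccccc1)N1C(=O)/C(=C\c2ccccn2)c2ccccc21`, differs from compound 2 by pyridin-2-yl in place of pyridin-3-yl on a double-bonded chain carbon bound to a double-bonded ring carbon. Among the compounds with values here, no step between measured compounds isolates this change, and the two measured numbers sit close together, so no step beyond the scatter is expected for compound 3 in this assay. The expected step from compound 2 to compound 3 is a 1.0-fold higher number from compound 2 to compound 3 (0.01 log units; within the scatter). Compound 3 is therefore estimated at 3400 nM, with a range from 1700 nM to 7000 nM.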

Compound 3, half-maximal inhibitory concentration: 5900 nM
Compound 3: middle estimate off by 1.7-fold (0.24 log units), on the low side, within the range that was stated.
By their numbers in this assay, from the lowest: compounds 2, 1 and 3 (each within the scatter of the next).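

In this assay, pyridin-2-yl in place of pyridin-3-yl on a double-bonded chain carbon bound to a double-bonded ring carbon gives a 1.8-fold higher number from compound 2 to compound 3 (0.25 log units; within the scatter) and so cannot be told from the scatter. Methyl in place of hydrogen on a saturated chain carbon bound to an amide-type nitrogen in a ring and an aromatic carbon gives a 1.6-fold higher number from compound 1 to compound 3 (0.21 log units; within the scatter) and likewise stays unresolved. No evidence bears on either step. As far as these compounds go, whether pyridin-4-yl, or an amine or carboxylic acid on the pyridin-2-yl ring, would give a step beyond the scatter remains open. So does the outcome of a longer chain in place of that methyl.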